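The source may hold more compounds than are shown below. What is called first, only, known or untested is meant among the compounds shown, and "the series" means these compounds.

Compound 2 `CCS[C@@H]1[C@H](SCC)[C@@H](Cn2cc(-c3cccc(C)c3)nn2)O[C@H]1n1ccc(=O)[nH]c1=O` and compound 1 `CCS[C@@H]1[C@H](SCC)[C@@H](Cn2cc(-c3ccc(F)cc3)nn2)O[C@H]1n1ccc(=O)[nH]c1=O` share one core and differ only in the aryl group on the five-membered aromatic ring with three nitrogen. In a functional assay on HepG2 cells (Homo sapiens) for cytotoxicity, read by MTT assay, with a stated time of 72 h (a lower number here means that less compound is needed, a higher number that more compound is needed for the effect), compound 1 gives 22600 nM, and compound 2 gives 18300 nM; the step of a 1.2-fold lower number from compound 1 to compound 2 (0.09 log units; within the scatter) leaves the two side by side. Compound 3 `CCS[C@@H]1[C@H](SCC)[C@@H](Cn2cc(-c3cccs3)nn2)O[C@H]1n1ccc(=O)[nH]c1=O` carries the change (thiophen-2-yl in place of 3-methylphenyl on an aromatic carbon). Among the compounds with values here, the only step that bears on it, an exchange of one aryl group for another, stayed within the scatter, so no step beyond the scatter is expected in this assay. Compound 3 is therefore expected at 19000 nM, between 7000 nM and 50000 nM, a step of a 1.0-fold higher number from compound 2 to compound 3 (0.02 log units; within the scatter).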

Compound 3, half-maximal effective concentration: 91800 nM
The estimate for compound 3 lay 4.8-fold (0.68 log units) below the measured number; measured number above the stated range.
By their numbers in this assay, from the lowest: compounds 2 and 1 (each within the scatter of the next); then compound 3.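

In this assay the group on this aromatic carbon proves less freely exchangeable than the earlier pair suggested: thiophen-2-yl brings a 5.0-fold higher number from compound 2 to compound 3 (0.70 log units; beyond the scatter) and a 4.1-fold higher number from compound 1 to compound 3 (0.61 log units; beyond the scatter) while the two substituted phenyl groups remain within the scatter of each other. Among the compounds shown, only the five-membered aromatic ring with 1 hetero atom moves the number beyond the scatter. Nothing available accounts for this shift. On these data alone, whether the sulfur or the smaller ring matters remains open, as does the standing of furan-2-yl, an unsubstituted phenyl or a phenyl carrying a carboxylic acid at this carbon.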